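The source may report more compounds than this note shows. Statements on the series, on what has been measured and on what is new or still open speak of the compounds shown alone.

Measured in a functional assay on HEK293 cells (Homo sapiens) for cytotoxicity; a higher number here means that more compound is tolerated, a lower number that less compound is tolerated:

- compound 1, `COc1ccc([C@H]2CC(=O)N(Cc3cccc(C#N)c3)C2)cc1OC1CCCC1`: compound 1 gives > 10000 nM, a limit of the assay.
- compound 2, `COc1ccc([C@H]2CC(=O)N(C(=O)c3ccccc3)C2)cc1OC1CCCC1`: compound 2 gives > 10000 nM, a limit of the assay.
- compound 3, `COc1ccc([C@H]2CC(=O)N(c3ccccc3)C2)cc1OC1CCCC1`: compound 3 gives > 10000 nM, a limit of the assay.

Compound 2 stands only at a limit in this assay, and the two further values shown are limits as well; all three sit at the limit of > 10000 nM in this assay, at which 3 of the 3 values shown sit. None of the steps among them can be read: a step that the two limits leave unreadable from compound 1 to compound 2, a step that the two limits leave unreadable from compound 1 to compound 3, a step that the two limits leave unreadable from compound 2 to compound 3. The step to compound 4, `COc1ccc([C@H]2CC(=O)N(c3cc(N)cc(F)c3)C2)cc1OC1CCCC1`, is 3-amino-5-fluorophenyl in place of benzoyl on an amide-type nitrogen in a ring. The change on the same amide-type nitrogen in a ring from compound 2 to compound 3, phenyl in place of benzoyl, gave no readable step, and the change to 3-amino-5-fluorophenyl is measured nowhere in the series. No step beyond the scatter in this assay is therefore expected, in either direction; the step from compound 2 to compound 4 is estimated as a step that the limit leaves unreadable from compound 2 to compound 4. Compound 4 is expected to give about 20000 nM in this assay, within 8000 nM to 60000 nM, most likely reported as a limit again.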

Compound 4, half-maximal cytotoxic concentration: > 10000 nM
Compound 4 was reported as a limit; the forecaster's own chance of this, stated with the estimate: 80%; the middle value is on the limit's open side.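

In this assay compound 4 gives > 10000 nM, a limit of the assay. Going by these compounds alone, no step linking compound 4 to compound 1, compound 2 or compound 3 can be read: the limit of > 10000 nM in this assay, at which 4 of the 4 values shown sit. The compounds shown leave open at what concentration any of them becomes cytotoxic, and whether the groups on the amide-type nitrogen differ at all.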